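Carboxymethyl to 1-carboxyethyl on compound 2

A few compounds are considered here, and "the series" means these few. Any claim that something is new, unique, unknown or untested is made for them only; others in the source may bear on it.

In a physicochemical assay for lipophilicity, at pH 7.4 (on this read-out lower numbers stand for lower lipophilicity and higher numbers for higher lipophilicity), compound 2 `O=C(O)Cn1nc(Cn2cc3cc(OCC4CC4)c(Cl)cc3n2)c2ccccc2c1=O` gives 2.79 and holds the higher of the two measured numbers. Compound 1 `O=C(O)Cn1nc(Cc2nc3cc(Cl)c(OCC(F)F)cc3[nH]2)c2ccccc2c1=O` gives 1.97 and sits lower by a gap beyond the scatter. For the measured compounds named here, these two compounds differ in more than one place, so the series offers no measured single-change step to guide the next comparison. The step to compound 3 `C[C@H](C(=O)O)n1nc(Cn2cc3cc(OCC4CC4)c(Cl)cc3n2)c2ccccc2c1=O` is methyl in place of hydrogen on a saturated chain carbon bound to an aromatic nitrogen and a carbonyl carbon and amounts to methyl in place of hydrogen on a saturated chain carbon bound to an aromatic nitrogen and a carbonyl carbon. Going by the values given here, with only that structural change to go on, a small rise in this assay is expected, an estimated a number 0.31 log units higher from compound 2 to compound 3 (beyond the scatter) and little more. Compound 3 is estimated at 3.1 with 2.8 to 3.5 as the expected range.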

Compound 3, distribution coefficient: 2.99
Compound 3: the middle estimate sits 0.11 log units above what was measured, within the range that was stated.
By their numbers in this assay, from the lowest: compound 1; then compounds 2 and 3 (each within the scatter of the next).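

Working notes: the series now has its first single-place step. In this assay, methyl in place of hydrogen on a saturated chain carbon bound to an aromatic nitrogen and a carbonyl carbon gives a number 0.20 log units higher from compound 2 to compound 3 (within the scatter). This position can therefore take the change from carboxymethyl to 1-carboxyethyl, on this core, with compound 3 remaining within the scatter of compound 2 on this read-out. No measured information bears on what lies behind this step.

Open, as far as these compounds go, is whether ethyl or an aminomethyl group in place of this methyl on the same carbon would also remain within the scatter of compound 2. Also open, from the compounds shown here alone, is whether the same methyl on the core of compound 1 would give a step of similar size.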